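Moving the hydroxy group out of the 2-position

A few compounds are considered here, and "the series" means these few. Any claim that something is new, unique, unknown or untested is made for them only; others in the source may bear on it.

Compound 3, `CC(O)(C(=O)Nc1ccc(S(=O)(=O)c2ccccc2O)cc1)C(F)(F)F`, gives 3090 nM in a functional assay (Cavia porcellus) with sulfonylurea receptors; K-ATP channels (Homo sapiens) as the target (on this read-out higher numbers stand for weaker inhibition and lower numbers for stronger inhibition), the higher of the two numbers measured in this series; compound 1, `CC(O)(C(=O)Nc1ccc(S(=O)(=O)c2ccccc2C#N)cc1)C(F)(F)F`, stands closer at 1100 nM, a step of a 2.8-fold higher number from compound 1 to compound 3 (0.45 log units; beyond the scatter) for hydroxy in place of cyano on an aromatic carbon. Compound 2, `CC(O)(C(=O)Nc1ccc(S(=O)(=O)c2ccc(C#N)cc2)cc1)C(F)(F)F`, reaches only the limit (the limit of > 30000 nM in this assay, at which 1 of the 3 values shown sits), so its value of > 30000 nM is a limit and not a number. Compound 4 is `CC(O)(C(=O)Nc1ccc(S(=O)(=O)c2cccc(O)c2)cc1)C(F)(F)F`; (3-hydroxyphenyl in place of 2-hydroxyphenyl on a sulfonyl sulfur).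

The step that bears on this change is an at least 27-fold higher number from compound 1 to compound 2 (1.43 log units; beyond the scatter): moving the substituent away from the 2-position on the sulfonyl-linked ring weakened inhibition strongly, and an at least 9.7-fold lower number from compound 2 to compound 3 (0.98 log units; beyond the scatter) shows the return to a 2-substituted ring recovering much of it. A move to the 3-position is expected to cost as well, though less than the full move to the 4-position. The estimated step is a 3.9-fold higher number from compound 3 to compound 4 (0.59 log units; beyond the scatter), toward weaker inhibition. Compound 4 is therefore expected at about 12000 nM, within 4000 nM to 35000 nM.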

Compound 4, half-maximal inhibitory concentration: 18000 nM
Beside the measured number, compound 4's estimate is 1.5-fold (0.18 log units) below it; the measured number falls inside the stated range.
By their numbers in this assay, from the lowest: compound 1; then compound 3; then compound 4. At a limit, above all of these: compound 2.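

In this assay, 3-hydroxyphenyl in place of 2-hydroxyphenyl on the sulfonyl sulfur gives a 5.8-fold higher number from compound 3 to compound 4 (0.77 log units; beyond the scatter) with the atoms and the donor and acceptor counts unchanged, so the place of the hydroxy group alone separates these two compounds. Set against the 2-cyanophenyl ring, the 3-hydroxyphenyl ring gives a 16-fold higher number from compound 1 to compound 4 (1.21 log units; beyond the scatter) as a larger step, and both 2-substituted rings now give lower numbers than compound 4. Compound 2 remains a limit and not a number, and an at least 1.6-fold lower number from compound 2 to compound 4 (0.22 log units; that floor lies within the scatter) leaves its order against compound 4 unresolved.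

On these data alone, how 4-hydroxyphenyl, 3-cyanophenyl or an amine or carboxylic acid on this ring would read remains open. Nothing shown here gives a cause for the step between compound 3 and compound 4.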